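A few compounds are considered here, and "the series" means these few. Any claim that something is new, unique, unknown or untested is made for them only; others in the source may bear on it.

Measured compounds:
compound 1, `C[C@@H](NC(=O)[C@H](CCCNC(=N)N)NC(=O)c1ccc(CN(Cc2ccncc2)Cc2ccc(F)cc2)cc1)c1cccc2ccccc12`, 39000 nM
compound 2, `C[C@@H](NC(=O)[C@H](CCCNC(=N)N)NC(=O)c1ccc(CN(Cc2ccncc2)C(=O)c2ccc(F)cc2)cc1)c1cccc2ccccc12`, 45000 nM
compound 3, `C[C@H](NC(=O)[C@H](CCCNC(=N)N)NC(=O)c1ccc(CN(Cc2ccc(F)cc2)Cc2ccccn2)cc1)c1cccc2ccccc12`, 11000 nM

All three were run in an ADME assay on MT4 cells (Homo sapiens) for cytotoxicity; a higher number here means that more compound is tolerated, a lower number that less compound is tolerated. Compound 1 and compound 2 differ in one place, ((4-fluorophenyl)carbonyl in place of 4-fluorobenzyl on an amine nitrogen), and the step of a 1.2-fold higher number from compound 1 to compound 2 (0.06 log units; within the scatter) shows that this exchange left the half-maximal cytotoxic concentration essentially unchanged. Compound 3 has the same atoms as compound 1, joined differently; the difference between the two cores is not broken down here. Its number is the lowest of the three, with compound 1 nearest and compound 2 furthest, both beyond the scatter.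

Compound 4, `C[C@H](NC(=O)[C@H](CCCNC(=N)N)NC(=O)c1ccc(CN(Cc2ccccn2)C(=O)c2ccc(F)cc2)cc1)c1cccc2ccccc12`, is not yet measured. It relates to compound 3 as compound 2 relates to compound 1: (4-fluorophenyl)carbonyl in place of 4-fluorobenzyl on an amine nitrogen, at a place described in the same words in both pairs, so this is the same change. Because a 1.2-fold higher number from compound 1 to compound 2 (0.06 log units; within the scatter) was within the scatter, the step from compound 3 to compound 4 is also expected to be small, a 1.2-fold higher number from compound 3 to compound 4 (0.07 log units; within the scatter). For compound 4 the estimated value in this assay is 13000 nM, with a range from 6000 nM to 28000 nM.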

Compound 4, half-maximal cytotoxic concentration: 37000 nM
Beside the measured number, compound 4's estimate is 2.8-fold (0.45 log units) below it; measured number outside the range, above it.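

In this assay, (4-fluorophenyl)carbonyl in place of 4-fluorobenzyl on the amine nitrogen gives a 3.4-fold higher number from compound 3 to compound 4 (0.53 log units; beyond the scatter), so the exchange is not silent on this core. The step does not carry over in size from one core to the other: the same change on two cores in this assay, a 1.2-fold higher number (0.06 log units; within the scatter) from compound 1 to compound 2 and a 3.4-fold higher number (0.53 log units; beyond the scatter) from compound 3 to compound 4, 2.9-fold (0.46 log units) apart, beyond the scatter of two such steps. With a single pair on each core, this shows that a step read on one core cannot be taken as the size of the step on the other, but it does not show which of the differences in the two cores sets the gap, or how the exchange would behave on any further core.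

Still open, going by these compounds, is how the cores respond to other groups on that amine nitrogen, such as a sulfonyl group in place of the carbonyl, or a plain methyl in place of the 4-fluorobenzyl. Also open, on these data alone, is whether the two cores would part in the same way with such groups.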